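A few compounds are considered here, and "the series" means these few. Any claim that something is new, unique, unknown or untested is made for them only; others in the source may bear on it.

Compound 1 `CCOC(=O)N1N=C(c2ccccc2)CC1c1cc(OC)c(OC)c(OC)c1`: 5610 nM
Compound 2 `COC(=O)N1N=C(c2cccc(OC)c2)CC1c1cc(OC)c(OC)c(OC)c1`: 350 nM

In a functional assay on MDA-MB-231 cells (Homo sapiens) for antiproliferative activity, read by MTT assay, with a stated time of 48 h (on this read-out lower numbers stand for stronger inhibition of growth and higher numbers for weaker inhibition of growth), compound 2 gives the lowest of the two numbers, 350 nM, and the gap to compound 1 at 5610 nM lies beyond the scatter. Compound 3 `CCOC(=O)N1N=C(c2cccc(OC)c2)CC1c1cc(OC)c(OC)c(OC)c1` has methoxycarbonyl changed to ethoxycarbonyl, with methyl in place of hydrogen on a saturated chain carbon bound to an oxygen next to a carbonyl group. Among the compounds with values here, no measured pair isolates this change. Compound 1 also carries ethoxycarbonyl, but it differs from compound 2 elsewhere too. In this assay the expected step is small and toward a higher number: a 1.7-fold higher number from compound 2 to compound 3 (0.23 log units; within the scatter). For compound 3 the estimate is 600 nM, with an expected range of 200 nM to 1800 nM.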

Compound 3, concentration for 50% growth inhibition: 9100 nM
Compound 3: the middle estimate sits 15-fold (1.18 log units) below what was measured; measured number above the stated range.
By their numbers in this assay, from the lowest: compound 2; then compounds 1 and 3 (each within the scatter of the next).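

In this assay, the exchange of methoxycarbonyl for ethoxycarbonyl now stands alone, and a single added methyl on a saturated chain carbon bound to an oxygen next to a carbonyl group gives a large step (a 26-fold higher number from compound 2 to compound 3 (1.41 log units; beyond the scatter)). With ethoxycarbonyl held in place, methoxy in place of hydrogen on an aromatic carbon gives no step beyond the scatter (a 1.6-fold higher number from compound 1 to compound 3 (0.21 log units; within the scatter)). No measured evidence bears on the reason for the large step.

The compounds shown leave open how a longer chain such as propoxycarbonyl, or a carboxylic acid, would read at this place. They also leave open what methoxy on an aromatic carbon does when methoxycarbonyl is present.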